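Phenyl ester to propyl ketone on a long dienoate chain

This account rests on a few compounds, and the source may have more. Where it says the series, first, only, none or still open, it means among the compounds named here.

Measured compounds:
- compound 1, `CC(/C=C/CC(C)CCCC(C)C)=C\C(=O)Oc1ccccc1`: 7.67
- compound 2, `COC(CCC(C)C/C=C/C(C)=C/C(=O)OC(C)C)C(C)C`: 5.95

In a physicochemical assay for lipophilicity (a higher number here means a more lipophilic compound, a lower number a more polar compound), compound 1 gives 7.67 and is the higher of the two numbers at hand; compound 2, in the same assay, gives 5.95, and the gap between the two lies beyond the usual scatter. Compound 2 shares no single-point relation with compound 1, so its value serves only as a second anchor on the scale.

Compound 3, `CCCC(=O)/C=C(C)/C=C/CC(C)CCCC(C)C`, has not yet been measured. It is built from compound 1 by one change: propyl in place of phenoxy on a carbonyl carbon. The phenoxy group that leaves carries the aromatic ring and the one hydrogen-bond acceptor of that part; the propyl that enters carries fewer heavy atoms and no acceptor.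

Among the compounds with values here, no step between measured compounds covers this change, so the expected step rests on the reduction in heavy-atom count alone. For compound 3 a move downward in this assay is expected, beyond the scatter, as a number 1.07 log units lower from compound 1 to compound 3 (beyond the scatter). The estimate for compound 3 in this assay is 6.6, with a range from 5.9 to 7.3.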

Compound 3, partition coefficient: 6.81
Compound 3: middle estimate off by 0.21 log units, on the low side; measured number inside the range.
By their numbers in this assay, from the lowest: compound 2; then compound 3; then compound 1.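

In this assay, propyl in place of phenoxy on a carbonyl carbon gives the series its first step that can be read at a single position (a number 0.86 log units lower from compound 1 to compound 3 (beyond the scatter)), which compound 2 could not provide as a second anchor on the scale. The number at this position therefore moves with this exchange, and compound 3 still stands at a high absolute value (6.81) with propyl, which has no ring and no hydrogen-bond acceptor. The exchange changes the heavy-atom count, the aromatic ring and the acceptor together, so this one step cannot be divided among them, and nothing measured here bears on its origin.

Plain phenyl or benzyl on the same carbonyl carbon would separate the ring from the oxygen, while ethoxy or propoxy would keep the oxygen without the ring, so those pairs would show how much of the step belongs to each. As far as these compounds go, how this assay responds at this position to a longer chain, an amine or a carboxylic acid remains open, as does whether the step carries over to a different core.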